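The compounds below may be only part of what the source reports. "The series", "measured", "known", "first", "only" and "open" are said of these compounds alone.

In a functional assay on K562 cells (Homo sapiens) for cytotoxicity, in the presence of a further agent that is not named here (a lower number here means a stronger inhibitor, a higher number a weaker inhibitor), compound 1 `Clc1ccc(-c2cc(-c3ccc(Cl)o3)cc(-c3cccs3)n2)cc1` gives 20900 nM, compound 2 `Cc1cccc(-c2cc(-c3ccc(Cl)o3)cc(-c3ccsc3)n2)c1` gives 20200 nM, and compound 3 `Clc1ccc(-c2cc(-c3ccc(Cl)o3)cc(-c3ccsc3)n2)cc1` gives 18700 nM. Compound 3 holds the lowest of these three numbers, but both neighbours sit within the scatter: a 1.1-fold lower number from compound 1 to compound 3 (0.05 log units; within the scatter) and a 1.1-fold lower number from compound 2 to compound 3 (0.03 log units; within the scatter). Compound 4 `Clc1ccc(-c2cc(-c3ccsc3)nc(-c3ccco3)c2)o1` differs from compound 3 in one place: furan-2-yl in place of 4-chlorophenyl on an aromatic carbon. Among the compounds with values here, only one measured step bears on this aromatic carbon, the exchange of 3-methylphenyl for 4-chlorophenyl, and it stayed within the scatter; no measured step brings in furan-2-yl, so no direction can be read from these numbers. The step expected in this assay is a 1.1-fold higher number from compound 3 to compound 4 (0.03 log units; within the scatter), meaning nothing beyond the scatter. The estimate for compound 4 is 20000 nM, between 8000 nM and 50000 nM.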

Compound 4, half-maximal inhibitory concentration: 22400 nM
Beside the measured number, compound 4's estimate is 1.1-fold (0.05 log units) below it, within the range that was stated.
By their numbers in this assay, from the lowest: compounds 3, 2, 1 and 4 (each within the scatter of the next).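

In this assay, furan-2-yl on the aromatic carbon next to the ring nitrogen gives a 1.2-fold higher number from compound 3 to compound 4 (0.08 log units; within the scatter) and a 1.1-fold higher number from compound 2 to compound 4 (0.04 log units; within the scatter). So this position now shows a change of ring type, not only of the substituent on a phenyl ring: a five-membered aromatic ring with a hydrogen-bond acceptor replaces a six-membered carbon ring, and the number stays within the scatter. Nothing shown here offers an explanation for this. On these data alone, whether an amine or a carboxylic acid at this position would move the number beyond the scatter remains open.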